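Compound 4: acetoxymethyl in place of methoxymethyl

This account rests on a few compounds, and the source may have more. Where it says the series, first, only, none or still open, it means among the compounds named here.

Compound 1 `CCOc1c(-c2occ(C)c2C(=O)OC)ccc2c(CC)cccc12` gives 1.9 ug/mL in a functional assay on DU-145 cells (Homo sapiens) for cytotoxicity, read by MTT assay, with a stated time of 72 h; a lower number here means that less compound is needed, a higher number that more compound is needed for the effect.
Compound 2 `CCOc1c(-c2occ(C)c2CO)ccc2c(CC)cccc12` gives only a limit in this assay, namely > 10 ug/mL.
Compound 3 `CCOc1c(-c2occ(C)c2COC)ccc2c(CC)cccc12` gives only a limit in this assay, namely > 10 ug/mL.

Compound 3 therefore stands at the limit of this assay rather than at a number, as shown by the limit of > 10 ug/mL in this assay, at which 2 of the 3 values shown sit. Compound 2 shares that limit, so the step that the two limits leave unreadable from compound 2 to compound 3 cannot be read. Compound 4 `CCOc1c(-c2occ(C)c2COC(C)=O)ccc2c(CC)cccc12` differs from compound 3 by acetyl in place of methyl on an oxygen on a saturated carbon. Going by the values given here, the steps that bear on this spot are an at least 5.2-fold higher number from compound 1 to compound 2 (0.72 log units; beyond the scatter) and an at least 5.2-fold higher number from compound 1 to compound 3 (0.72 log units; beyond the scatter): each time the methoxycarbonyl of compound 1 was replaced, the number rose beyond the scatter. Among the compounds with values here, compound 4 brings back a carbonyl, but as an acetyl on the oxygen rather than as methoxycarbonyl, and no measured step tells whether this recovers the low number of compound 1. Compound 4 is expected to stay near the limit, with the step that the limit leaves unreadable from compound 3 to compound 4 expected to be small. Compound 4 is estimated at 12 ug/mL, between 4 ug/mL and 40 ug/mL.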

Compound 4, concentration for half-maximal effect: > 10 ug/mL
Compound 4 ended at the assay's limit; the forecaster's own chance of this, stated with the estimate: 60%; the middle value lies beyond the limit too.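

A carbonyl on this side chain is not enough by itself: acetoxymethyl carries one, yet putting it in place of methoxycarbonyl gives an at least 5.2-fold higher number from compound 1 to compound 4 (0.72 log units; beyond the scatter). Of the four groups shown at this position, only methoxycarbonyl goes with a readable number in this assay, so the carbonyl alone does not account for that number. Compound 4 gives only a limit, the same limit as compound 2 and compound 3: the limit of > 10 ug/mL in this assay, at which 3 of the 4 values shown sit.

From the compounds shown here alone, the steps among compound 2, compound 3 and compound 4 cannot be read, so it stays open whether these three differ at all. Also open, going by these compounds, is whether a carboxylic acid or an amide in place of methoxycarbonyl would give a number as low as that of compound 1 at 1.9 ug/mL.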